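Replacing 2,3-dimethoxyphenyl with 1H-indol-3-yl

A few compounds are considered here, and "the series" means these few. Any claim that something is new, unique, unknown or untested is made for them only; others in the source may bear on it.

In a functional assay on SMMC-7721 cells (Homo sapiens) for cytotoxicity, read by MTT assay, with a stated time of 72 h (a higher number here means a weaker inhibitor, a lower number a stronger inhibitor), compound 1 `O=C1C(=Cc2ccc(F)cc2)C(=O)N(c2ccc(Cl)cc2)N1c1ccc(Cl)cc1` gives 23300 nM and compound 2 `COc1cccc(C=C2C(=O)N(c3ccc(Cl)cc3)N(c3ccc(Cl)cc3)C2=O)c1OC` gives 14100 nM. These two values are all that is known so far, and they sit within the scatter of each other, so compound 2 cannot be ranked apart from compound 1. Compound 3 `O=C1C(=Cc2c[nH]c3ccccc23)C(=O)N(c2ccc(Cl)cc2)N1c1ccc(Cl)cc1` keeps the shared core and changes one group: 1H-indol-3-yl in place of 2,3-dimethoxyphenyl on a double-bonded chain carbon bound to a double-bonded ring carbon. The change falls on a double-bonded chain carbon bound to a double-bonded ring carbon. For the measured compounds named here, the one measured step at that place, a 1.7-fold lower number from compound 1 to compound 2 (0.22 log units; within the scatter), stayed within the scatter. Going by the values given here, no measured compound carries 1H-indol-3-yl, so this single step is thin guidance. With that caution, no shift beyond the scatter is expected in this assay, in either direction, and the expected step is a 1.1-fold lower number from compound 2 to compound 3 (0.04 log units; within the scatter). For compound 3 the estimated value is 13000 nM, with an expected range of 4500 nM to 35000 nM.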

Compound 3, half-maximal inhibitory concentration: 19600 nM
Beside the measured number, compound 3's estimate is 1.5-fold (0.18 log units) below it; the measured number falls inside the stated range.
By their numbers in this assay, from the lowest: compounds 2, 3 and 1 (each within the scatter of the next).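

In this assay, 1H-indol-3-yl on a double-bonded chain carbon bound to a double-bonded ring carbon gives a 1.4-fold higher number from compound 2 to compound 3 (0.14 log units; within the scatter) and a 1.2-fold lower number from compound 1 to compound 3 (0.08 log units; within the scatter). For the compounds shown here, this place has therefore now carried three different groups with no step leaving the scatter. That holds even for a change that brings in a five-membered aromatic ring with 1 hetero atom and a hydrogen-bond donor, while the 2 hydrogen-bond acceptors of 2,3-dimethoxyphenyl leave (no evidence bearing on this result is available).

From the compounds shown here alone, whether any group at this place can move the number beyond the scatter remains open, for instance one carrying an amine or a carboxylic acid. All three compounds also keep the shared core, so what a change elsewhere would do is open too.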